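The source may hold more compounds than are shown below. What is called first, only, known or untested is meant among the compounds shown, and "the series" means these compounds.

Among the compounds with values here, compound 2 `O=C(C1=C(Nc2cccc(Br)c2)C(=O)N(CCCn2ccnc2)C1c1ccc(Br)cc1)c1ccccc1` gives 9090 nM in a functional assay on SAOS-2 cells (Homo sapiens) for antiproliferative activity, read by MTT assay, with a stated time of 72 h (a lower number here means a stronger inhibitor, a higher number a weaker inhibitor), the lowest of the two numbers so far; compound 1 `NC1=C(C(=O)c2ccccc2)C(c2ccc(Br)cc2)N(CCCn2ccnc2)C1=O` gives 107000 nM, and the step of a 12-fold lower number from compound 1 to compound 2 (1.07 log units; beyond the scatter) came with 3-bromophenyl in place of hydrogen on an amine nitrogen. Compound 3 `O=C(C1=C(Nc2ccccc2Br)C(=O)N(CCCn2ccnc2)C1c1ccc(Br)cc1)c1ccccc1` differs from compound 2 only in the ring position of the bromine: 2-bromophenyl in place of 3-bromophenyl on an amine nitrogen. No measured step moves a substituent around this ring, so nothing shown speaks to the size of this change; the only measured step concerns adding the ring itself. The expected step of a 1.2-fold higher number from compound 2 to compound 3 (0.08 log units; within the scatter) is therefore none beyond the scatter. For compound 3 the estimate in this assay is 11000 nM, with a range of 3000 nM to 40000 nM.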

Compound 3, half-maximal inhibitory concentration: 19600 nM
The estimate for compound 3 lay 1.8-fold (0.25 log units) below the measured number; the range from low to high includes it.
By their numbers in this assay, from the lowest: compound 2; then compound 3; then compound 1.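

In this assay the place of the bromine on this ring matters, not only the presence of the ring (a 2.2-fold higher number from compound 2 to compound 3 (0.33 log units; beyond the scatter)). The 2-bromophenyl group still improves on the hydrogen of the primary amine (a 5.5-fold lower number from compound 1 to compound 3 (0.74 log units; beyond the scatter)), although this step is modest while the step to the 3-bromophenyl group is large. Nothing available explains the difference between the two bromine positions.

Open, on these data alone, is whether the bromine is needed at all, as an unsubstituted phenyl or a benzyl on this nitrogen would show. Also open, as far as these compounds go, is whether chlorine or methoxy on the same ring follows the same order.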